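Desmethyl analogue of compound 1 in the cytotoxicity series

A few compounds are considered here, and "the series" means these few. Any claim that something is new, unique, unknown or untested is made for them only; others in the source may bear on it.

Compound 1 `Cc1ccc(-c2cs/c(=N/NC(=O)CSc3nnnn3-c3ccccc3)n2-c2ccccc2)cc1` carries a 4-methylphenyl on the shared core. In an ADME assay on NIH3T3 cells (Mus musculus) for cytotoxicity, read by MTT assay, with a stated time of 24 h (on this read-out higher numbers stand for weaker inhibition and lower numbers for stronger inhibition), compound 1 reaches only the limit of the measurement, > 500 ug/mL, so no number stands for it. Two related compounds mark out the range seen so far. Compound 2 `O=C(CSc1ncccn1)N/N=c1/scc(-c2ccc(Br)cc2)n1-c1ccccc1` gives 273 ug/mL in this assay. Compound 3 `O=C(CSc1ncccn1)N/N=c1/scc(-c2ccc(F)cc2)n1-c1ccccc1` likewise sits at the limit of this assay, > 500 ug/mL. Within the data shown here, the one single-place step among the measured compounds, fluoro in place of bromo on an aromatic carbon, runs as an at least 1.8-fold higher number from compound 2 to compound 3 (0.26 log units; that floor lies within the scatter); its floor lies within the scatter, so it carries no step of settled size or direction. the limit of > 500 ug/mL in this assay, at which 2 of the 3 values shown sit, is where most of the measured values stop.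

Compound 4 `O=C(CSc1nnnn1-c1ccccc1)N/N=c1/scc(-c2ccccc2)n1-c1ccccc1` differs from compound 1 in one place: hydrogen in place of methyl on an aromatic carbon, or, cut one bond further out, 4-methylphenyl to phenyl. Among the measured compounds shown here, no measured step touches this methyl, and the bromo-to-fluoro step gives no direction beyond the scatter. Compound 4 is expected to stay close to the limit where compound 1 stands, with a step of a number no higher from compound 1 to compound 4 (the limit leaves the size open) of no more than the scatter. Compound 4 is therefore estimated at 500 ug/mL, within 250 ug/mL to 1000 ug/mL, and most likely reported again only as a limit.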

Compound 4, half-maximal inhibitory concentration: 417 ug/mL
Compound 4: middle estimate off by 1.2-fold (0.08 log units), on the high side, and the stated range covers the measured number.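

With hydrogen in place of methyl on an aromatic carbon, the series now has a direct reading at this position in this assay: an at least 1.1-fold lower number from compound 1 to compound 4 (0.07 log units; that floor lies within the scatter). Compound 4 gives 417 ug/mL, so the phenyl analogue yields a number on this read-out. The floor of the step lies within the scatter, so it settles neither a real change nor its direction. Compound 1 remains a limit, which leaves the upper end of the step open: the limit of > 500 ug/mL in this assay, at which 2 of the 4 values shown sit.

Still open, on these data alone, is whether another group on this aromatic carbon, such as an amine, a carboxylic acid or a longer alkyl chain, would move the number clearly beyond the scatter from the value of compound 4. Also open is whether 4-methylphenyl to phenyl reads the same with the side chain carried by compound 2 and compound 3, as the compounds shown hold this change on a single side chain.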